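Notes on compound 4 within the aryl-ether series

The source may hold more compounds than are shown below. What is called first, only, known or untested is meant among the compounds shown, and "the series" means these compounds.

Compound 3 `O=C(O)c1cc(-c2cccc(COc3ccc4c(=O)n(C5CCCC5)sc4c3)c2)ccc1F` gives 71% in an ADME assay on microsomes from liver (Rattus norvegicus) for metabolic stability, read by LC-MS, with a stated time of 1 h, at 37 degrees C, tested at 4 uM (on this read-out higher numbers stand for a more stable compound and lower numbers for a less stable compound), the second highest of the three numbers. Compound 2 `COc1ccc(-c2cccc(COc3ccc4c(c3)CN(C3CCCC3)C4=O)c2)cc1C(=O)O` gives 84%, and compound 1 `O=C(O)c1ccc(-c2cccc(COc3ccc4c(c3)CN(C3CCCC3)C4=O)c2)c(Cl)c1` gives 3%; compound 3 sits beyond the scatter from both of them. Compound 4 `Cc1ccc(C(=O)O)cc1-c1cccc(COc2ccc3c(=O)n(C4CCCC4)sc3c2)c1` differs from compound 3 in one place: 5-carboxy-2-methylphenyl in place of 3-carboxy-4-fluorophenyl on an aromatic carbon. Within the data shown here, the only measured step, a number 81 percentage points higher from compound 1 to compound 2 (beyond the scatter), changes the same terminal aryl group on a different core and shows that this position can move the read-out a long way. Among the measured compounds shown here, no step matches the present exchange, so its direction is open. A moderate downward step with wide uncertainty is expected, a number 13 percentage points lower from compound 3 to compound 4 (beyond the scatter). The estimate for compound 4 is 58%, with a range from 30% to 85%.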

Compound 4, percent of the compound remaining: 92%
The estimate for compound 4 lay 34 percentage points below the measured number, outside the stated range (above it).
By their numbers in this assay, from the lowest: compound 1; then compound 3; then compounds 2 and 4 (each within the scatter of the next).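

Exchanging 3-carboxy-4-fluorophenyl for 5-carboxy-2-methylphenyl in this assay gives a number 21 percentage points higher from compound 3 to compound 4 (beyond the scatter) on the core shared by these two compounds. The terminal aryl group therefore moves this read-out on a second core, not only on the core of compound 1. Nothing at hand bears on the cause of this step.

On these data alone, the exchange alters the fluorine, the methyl group and the place of the carboxylic acid together, so their separate contributions stay open. As far as these compounds go, how an ethyl group or an amine in place of the methyl group would read on this core is also open.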